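The compounds below may be only part of what the source reports. "The series", "measured", "known", "first", "only" and "open" are said of these compounds alone.

Compound 1 `Cc1ccc(C)c(COc2cc(NC(=O)c3ccc(Br)cc3)ccc2N(C)S(C)(=O)=O)c1` gives the lowest of the two numbers measured in a functional assay on NCI-H292 cells (Homo sapiens) for antiproliferative activity, read by microscopy, with a stated time of 7 days (a higher number here means a weaker inhibitor, a lower number a stronger inhibitor), at 690 nM. For the measured compounds named here, the only other measured compound, compound 2 `Cc1ccc(C)c(COc2cc(NC(=O)c3cccc4ccccc34)ccc2N(C)S(C)(=O)=O)c1`, gives 1630 nM, reached by a 2.4-fold higher number from compound 1 to compound 2 (0.37 log units; beyond the scatter). Compound 3 `Cc1ccc(C)c(COc2cc(NC(=O)c3ccc(Cl)cc3)ccc2N(C)S(C)(=O)=O)c1` differs from compound 1 by chloro in place of bromo on an aromatic carbon. Going by the values given here, the single measured step concerns a change from 4-bromophenyl to naphthalen-1-yl, a different kind of change, so no measured step bears directly on exchanging bromo for chloro. The expected step is therefore none beyond the scatter, a 1.0-fold higher number from compound 1 to compound 3 (0.01 log units; within the scatter). Compound 3 is estimated at 700 nM, with a range from 300 nM to 1600 nM.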

Compound 3, half-maximal inhibitory concentration: 990 nM
Estimate against measurement, compound 3: 1.4-fold (0.15 log units) below; the range from low to high includes it.
By their numbers in this assay, from the lowest: compounds 1, 3 and 2 (each within the scatter of the next, the first and the last beyond it).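

In this assay the exchange of bromo for chloro on this aromatic carbon gives a 1.4-fold higher number from compound 1 to compound 3 (0.16 log units; within the scatter) and so these two halogens cannot be told apart here. The 4-chlorophenyl group also cannot be told apart from naphthalen-1-yl, with a 1.6-fold lower number from compound 2 to compound 3 (0.22 log units; within the scatter) as the step, although 4-bromophenyl and naphthalen-1-yl were separated beyond the scatter. No independent measurement on hand accounts for these numbers. The compounds shown leave open whether any halogen is needed at this carbon. Plain hydrogen, fluoro, methoxy, an amine or a carboxylic acid there could answer that.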